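This account rests on a few compounds, and the source may have more. Where it says the series, first, only, none or still open, it means among the compounds named here.

Measured so far:
Compound 1 `O[C@H](c1ccccn1)[C@]1(c2cccc(OC(F)(F)F)c2)C[C@@H](O)C1` in an assay on HEK293 cells for antagonist activity at transient receptor potential cation channel subfamily V member 3 (Homo sapiens), read by FLIPR and calcium flux; a higher number here means a weaker inhibitor, a lower number a stronger inhibitor: 80 nM
Compound 2 `OC(c1ccccn1)C1(c2ccccc2OC(F)(F)F)CCC1` in this assay: 550 nM

Compound 1 holds the lower of the two numbers shown; compound 2 stands at a higher value, beyond the usual scatter, but the two differ in more than one place, so only their two values can be set side by side. Compound 3 `O[C@H](c1ccccn1)C1(c2cccc(OC(F)(F)F)c2)CCC1` has not been measured. It differs from compound 1 by hydrogen in place of hydroxy on a saturated ring carbon. Among the compounds with values here, no measured pair shows this change on its own, so there is no step to lean on. The expectation is a modest move toward a higher number, a step of a 2.0-fold higher number from compound 1 to compound 3 (0.30 log units; within the scatter) in this assay. Compound 3 is therefore estimated at 160 nM, with a range from 50 nM to 600 nM.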

Compound 3, antagonist equilibrium constant: 80 nM
For compound 3 the middle estimate is 2.0-fold (0.30 log units) above the measured one, within the range that was stated.
By their numbers in this assay, from the lowest: compounds 1 and 3 (each within the scatter of the next); then compound 2.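

In this assay, hydrogen in place of hydroxy on a saturated ring carbon of the four-membered ring gives no change at the digits printed from compound 1 to compound 3 (within the scatter). Within the data shown here, this is the first direct reading at this position, two ring bonds from the ring atom that bears the hydroxy(pyridin-2-yl)methyl group, and it shows that the hydroxy is not required for a value such as the 80 nM of compound 3. Nothing available explains why the two compounds cannot be told apart here.

From the compounds shown here alone, whether an amine, a carboxylic acid or a longer chain on this ring carbon would be tolerated equally remains open. Compound 2, at 550 nM, differs from both other compounds in more than one place, so the source of its higher number cannot be read.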